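From compound 2 to a methoxy analogue

The source may hold more compounds than are shown below. What is called first, only, known or untested is meant among the compounds shown, and "the series" means these compounds.

In a functional assay on SK-N-SH cells (Homo sapiens) for inhibition (a higher number here means a weaker inhibitor of growth, a lower number a stronger inhibitor of growth), compound 1 (`Cc1ccc(-n2sc3ncccc3c2=O)cc1`) gives 6200 nM and compound 2 (`O=c1c2cccnc2sn1-c1ccccc1`) gives 11200 nM in the same test. Within the data shown here, compound 2 therefore cannot be told apart from compound 1, the only other compound measured so far. The next compound, compound 3 (`COc1cccc(-n2sc3ncccc3c2=O)c1`), is still unmeasured. The change leading to it is methoxy in place of hydrogen on an aromatic carbon and amounts to methoxy in place of hydrogen on an aromatic carbon. Among the measured compounds shown here, no measured compound carries methoxy. For the measured compounds named here, the only guide is a single substitution on an aromatic carbon, where hydrogen in place of methyl gave a 1.8-fold higher number from compound 1 to compound 2 (0.26 log units; within the scatter) in this assay and so stayed small. A similarly small change is expected here, with the estimated step being a 1.4-fold lower number from compound 2 to compound 3 (0.15 log units; within the scatter) and no firm direction expected. For compound 3 the estimated value is 8000 nM with an expected range from 3500 nM to 18000 nM in this test.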

Compound 3, concentration for 50% growth inhibition: 6990 nM
Compound 3: middle estimate off by 1.1-fold (0.06 log units), on the high side; measured number inside the range.
By their numbers in this assay, from the lowest: compounds 1, 3 and 2 (each within the scatter of the next).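

With methoxy on an aromatic carbon of a six-membered aromatic ring of carbon only, meta to a large group, this assay shows a 1.6-fold lower number from compound 2 to compound 3 (0.20 log units; within the scatter), so adding this group at this place does not separate the two compounds. Together with a 1.8-fold higher number from compound 1 to compound 2 (0.26 log units; within the scatter), this gives two single changes on this ring, one involving methyl and one involving methoxy, and neither step goes beyond the scatter. Nothing available here accounts for this result.

From the compounds shown here alone, it remains open whether an amine, a carboxylic acid or a longer chain in the same place would produce a step beyond the scatter. Going by these compounds, it is also open whether methoxy on another aromatic carbon of this ring would behave as it does here.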